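A few compounds are considered here, and "the series" means these few. Any claim that something is new, unique, unknown or untested is made for them only; others in the source may bear on it.

Working notes on the series. The shared core of compound 1 `Cc1c(CO)cc2n1[C@@H](c1ccccc1)SC2` carries a methyl group and a hydroxymethyl group on the five-membered aromatic ring. In a functional assay on MCF7 cells (Homo sapiens) for cytotoxicity, read by MTT assay, with a stated time of 72 h (on this read-out higher numbers stand for weaker inhibition and lower numbers for stronger inhibition), compound 1 gives 2400 nM. Compound 2 `Cc1c(COC(=O)NCc2ccccc2)cc2n1[C@@H](c1ccccc1)SC2` carries a benzyl carbamate in place of the free hydroxymethyl of compound 1; in this assay compound 2 gives 2200 nM. The two numbers lie within the scatter of repeated measurements of each other, so no order between compound 1 and compound 2 can be drawn from them, and compound 1 cannot be placed apart from compound 2 on this read-out. Among the measured compounds shown here, no single-point step between measured compounds is available.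

Compound 3 `Cc1c(CO)c(CO)c2n1[C@@H](c1ccccc1)SC2` differs from compound 1 in one place: hydroxymethyl in place of hydrogen on an aromatic carbon. With no measured step of this kind in the series, the change is expected to move the number little, in no clear direction beyond the scatter. The step from compound 1 to compound 3 is estimated as no change at the digits printed from compound 1 to compound 3 (within the scatter). In this assay compound 3 is therefore expected to give 2400 nM, with a range from 800 nM to 7000 nM.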

Compound 3, half-maximal inhibitory concentration: 1000 nM
For compound 3 the middle estimate is 2.4-fold (0.38 log units) above the measured one; the range from low to high includes it.
By their numbers in this assay, from the lowest: compound 3; then compounds 2 and 1 (each within the scatter of the next).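

The aromatic carbon that carries hydrogen in compound 1, two ring bonds from the ring nitrogen, tolerates a substituent in this assay without loss: hydroxymethyl in place of hydrogen gives a 2.4-fold lower number from compound 1 to compound 3 (0.38 log units; beyond the scatter) and so provides the first modest separation in the series that lies beyond the scatter. The printed values of compound 1 and compound 2 could not show this, as they stand within the scatter of each other and concern the existing hydroxymethyl group rather than this aromatic carbon. The series holds no measurement that bears on the reason for the lower number.

Going by these compounds, a single step cannot separate the effect of the hydroxymethyl group itself from that of any substituent on this aromatic carbon, so it remains open whether an aminomethyl group, a carboxylic acid or a longer chain such as hydroxyethyl would shift the number in the same direction. On these data alone, it also remains open whether a benzyl carbamate built on this new hydroxymethyl group would keep the lower number.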